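This account rests on a few compounds, and the source may have more. Where it says the series, first, only, none or still open, it means among the compounds named here.

For the measured compounds named here, in a functional assay on Lu1 cells (Homo sapiens) for cytotoxicity, read by sulforhodamine B assay (on this read-out lower numbers stand for an effect already at smaller amounts and higher numbers for an effect only at larger amounts of compound), compound 1 (`C=C1CC[C@@H]2[C@](C)(CO)[C@H](OC(C)=O)CC[C@@]2(C)[C@@H]1C/C=C1/C(=O)OC[C@H]1O`) gives 30.6 uM and compound 2 (`C=C1CC[C@@H]2[C@](C)(CO[Si](C)(C)C(C)(C)C)[C@H](O)CC[C@@]2(C)[C@@H]1C/C=C1/C(=O)OC[C@H]1O`) gives 48.8 uM, so compound 2 lies within the usual scatter of the only other measured value. Compound 3 (`C=C1CC[C@@H]2[C@](C)(CO[Si](C)(C)C(C)(C)C)[C@H](OC(C)=O)CC[C@@]2(C)[C@@H]1C/C=C1/C(=O)OC[C@H]1O`) differs from compound 2 in one place: acetyl in place of hydrogen on an oxygen on a saturated carbon, or hydroxy to acetoxy. Going by the values given here, no measured step shows this change, so no step beyond the scatter, in either direction, is expected in this assay. The expected size is a 1.2-fold lower number from compound 2 to compound 3 (0.09 log units; within the scatter). For compound 3 the estimated value is 40 uM, with an expected range of 18 uM to 85 uM.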

Compound 3, concentration for half-maximal effect: 9.62 uM
Estimate against measurement, compound 3: 4.2-fold (0.62 log units) above; measured number outside the range, below it.
By their numbers in this assay, from the lowest: compound 3; then compounds 1 and 2 (each within the scatter of the next).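

In this assay hydroxy to acetoxy on an oxygen on a saturated carbon brings a 5.1-fold lower number from compound 2 to compound 3 (0.71 log units; beyond the scatter) with the group of 7 heavy atoms held in place. Putting that group on the other oxygen with the acetoxy held brings a 3.2-fold lower number from compound 1 to compound 3 (0.50 log units; beyond the scatter) as well. Compounds 1 and 2 each carry one of these groups and lie within the scatter of each other, while compound 3 carries both and stands apart; no measurement on hand bears on the reason. Open, from the compounds shown here alone, is whether a longer chain such as butyryl, or an amine, would serve in place of acetyl. Also open, going by these compounds, is how the core compares with free hydroxy on both oxygens.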